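The compounds below may be only part of what the source reports. "The series", "measured", "known", "first", "only" and "open" are said of these compounds alone.

Three compounds share one core and differ only in the group carried on a saturated chain carbon bound to a sulfur. Compound 1 `Cc1cc(Nc2cc(-c3ccccc3)[nH]n2)n2nc(SCCCc3ccccc3)nc2n1` carries a phenethyl group there, compound 2 `Cc1ccc(CSc2nc3nc(C)cc(Nc4cc(-c5ccccc5)[nH]n4)n3n2)cc1` a 4-methylphenyl group, and compound 3 `Cc1cc(Nc2cc(-c3ccccc3)[nH]n2)n2nc(SCc3csc4ccccc34)nc2n1` a 1-benzothiophen-3-yl group. In a functional assay on MGC-803 cells (Homo sapiens) for inhibition, read by MTT assay, with a stated time of 72 h (on this read-out lower numbers stand for stronger inhibition and higher numbers for weaker inhibition), compound 1 gives 6510 nM, compound 2 gives 6960 nM and compound 3 gives 2280 nM. Going by the values given here, compound 2 has the highest number of the three, but the step of a 1.1-fold higher number from compound 1 to compound 2 (0.03 log units; within the scatter) lies within the scatter, so compound 1 and compound 2 cannot be told apart; the step of a 3.1-fold lower number from compound 2 to compound 3 (0.48 log units; beyond the scatter) is the only one that separates compound 2 from another compound.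

Compound 4 `Cc1cc(Nc2cc(-c3ccccc3)[nH]n2)n2nc(SCc3cccc(Br)c3)nc2n1` keeps everything in compound 2 except (3-bromophenyl in place of 4-methylphenyl on a saturated chain carbon bound to a sulfur). Both steps that touch compound 2 bear on this change: a 1.1-fold higher number from compound 1 to compound 2 (0.03 log units; within the scatter) shows that exchanging the group on this carbon can leave the number where it was, while a 3.1-fold lower number from compound 2 to compound 3 (0.48 log units; beyond the scatter) shows that the 1-benzothiophen-3-yl group lowers it modestly. Among the compounds with values here, a 3-bromophenyl group has no precedent among the three, so no step beyond the scatter is expected, and compound 4 is expected to give 5000 nM, within 2000 nM to 12000 nM. That estimate means an expected step of a 1.4-fold lower number from compound 2 to compound 4 (0.14 log units; within the scatter).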

Compound 4, half-maximal inhibitory concentration: 4820 nM
The estimate for compound 4 lay 1.0-fold (0.02 log units) above the measured number, and the stated range covers the measured number.
By their numbers in this assay, from the lowest: compound 3; then compounds 4, 1 and 2 (each within the scatter of the next).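

In this assay, the exchange on this saturated chain carbon bound to a sulfur gives a 1.4-fold lower number from compound 2 to compound 4 (0.16 log units; within the scatter), and the comparison with the phenethyl group gives a 1.4-fold lower number from compound 1 to compound 4 (0.13 log units; within the scatter); both steps lie within the scatter, so compound 1, compound 2 and compound 4 cannot be told apart. A bromine-bearing ring therefore joins the 4-methylphenyl and phenethyl groups in this group of indistinguishable compounds, while the 1-benzothiophen-3-yl group stays apart, with a 2.1-fold higher number from compound 3 to compound 4 (0.33 log units; beyond the scatter), a modest step beyond the scatter that leaves compound 3 with a lower number than each of the other three. No experimental evidence is available here to explain why these groups give these numbers.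

The compounds shown leave open how a plain phenyl group or a naphthyl group would compare on this carbon, so the contribution of the bromine alone cannot be judged. They also leave open whether an amine, a carboxylic acid or a longer chain at this position would move the number beyond the scatter, in either direction.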